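A few compounds are considered here, and "the series" means these few. Any claim that something is new, unique, unknown or untested is made for them only; others in the source may bear on it.

Measured compounds in a functional assay on the whole organism (6C3HED cells, Mus musculus) for inhibition, at a dose of 300 mg/kg by the oral route; on this read-out higher numbers stand for more inhibition at the one dose given (going by the name of the read-out) and lower numbers for less inhibition:
compound 1 `CSc1ccc(S(=O)(=O)NC(=O)Nc2ccc(Cl)cc2)s1` gives 62%
compound 2 `CCOc1ccc(S(=O)(=O)NC(=O)Nc2ccc(Cl)cc2)s1` gives 96%
compound 3 `CC(C)(C)c1ccc(S(=O)(=O)NC(=O)Nc2ccc(Cl)cc2)s1` gives 10%

Compound 1 stands second highest of the three in this assay; compound 2 lies a number 34 percentage points higher from compound 1 to compound 2 (beyond the scatter), and compound 3 lies a number 52 percentage points lower from compound 1 to compound 3 (beyond the scatter). Between the other two, compound 3 lies a number 86 percentage points lower from compound 2 to compound 3 (beyond the scatter).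

Compound 4 `Cc1ccsc1S(=O)(=O)NC(=O)Nc1ccc(Cl)cc1` is not yet measured. It differs from compound 1 by 3-methylthiophen-2-yl in place of 5-(methylsulfanyl)thiophen-2-yl on a sulfonyl sulfur.

Among the measured compounds shown here, no measured step bears directly on this change: every measured step swaps one group for another at the same place on the shared core, while compound 4 carries a different group at a different place. What the measured steps do show is that changes on this part of compound 1 move this assay by large amounts in either direction. Compound 1 sits in the middle of that spread, so the expected step from it to compound 4 is a number 17 percentage points lower from compound 1 to compound 4 (beyond the scatter), with wide uncertainty. The expected value for compound 4 in this assay is 45%, between 10% and 85%.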

Compound 4, a percentage reported as inhibition, in the whole organism at one dose (the size of the read-out at that dose, not a potency): 62%
Estimate against measurement, compound 4: 17 percentage points below, and the stated range covers the measured number.
By their numbers in this assay, from the lowest: compound 3; then compounds 1 and 4 (each within the scatter of the next); then compound 2.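

Replacing 5-(methylsulfanyl)thiophen-2-yl with 3-methylthiophen-2-yl on the sulfonyl sulfur gives, in this assay, no change at the digits printed from compound 1 to compound 4 (within the scatter). Unlike the earlier swaps of one group for another, all of which moved the read-out beyond the scatter, this change shows that the methylsulfanyl group is not needed to keep the level of compound 1 at this dose, even though the entering group has fewer hydrogen-bond acceptors and a methyl group at a different place. Nothing measured here explains why the two groups read alike.

The compounds shown leave open whether an amine or a carboxylic acid in place of the methyl of 3-methylthiophen-2-yl would keep this level. They also leave open whether compound 1 and compound 4 would still match at other doses, since the read-out comes from a single dose.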